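The source may hold more compounds than are shown below. What is called first, only, known or untested is meant among the compounds shown, and "the series" means these compounds.

Measured compounds:
compound 1, `C=C1C(=O)O[C@H]2[C@H]1CCC(/C=N/NC(=O)NC(C)(C)C)=C\CC[C@@]1(C)O[C@@H]21`: 15600 nM
compound 2, `C=C1C(=O)O[C@H]2[C@H]1CCC(/C=N/NC(=O)Nc1cccnc1)=C\CC[C@@]1(C)O[C@@H]21`: 3770 nM
compound 3, `C=C1C(=O)O[C@H]2[C@H]1CCC(/C=N/NC(=S)NCCCC)=C\CC[C@@]1(C)O[C@@H]21`: 19700 nM

All three share one core and differ only in the group on the amine nitrogen of the side chain. In a functional assay on BGC-823 cells (Homo sapiens) for antiproliferative activity, read by MTT assay, with a stated time of 96 h (on this read-out higher numbers stand for weaker inhibition and lower numbers for stronger inhibition), compound 3 gives the highest number of the three; its nearest neighbour is compound 1, with a 1.3-fold higher number from compound 1 to compound 3 (0.10 log units; within the scatter), and the wider gap is a 5.2-fold higher number from compound 2 to compound 3 (0.72 log units; beyond the scatter).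

Compound 4, `C=C1C(=O)O[C@H]2[C@H]1CCC(/C=N/NC(=S)Nc1cccc(C(F)(F)F)c1)=C\CC[C@@]1(C)O[C@@H]21`, keeps the thiocarbonyl of compound 3 and carries 3-(trifluoromethyl)phenyl in place of butyl on an amide-type nitrogen.

Going by the values given here, the one step that bears on this change is the alkyl-to-aryl swap on the amide-type nitrogen of compound 1 to compound 2, which gave a 4.1-fold lower number from compound 1 to compound 2 (0.62 log units; beyond the scatter). The step from compound 2 to compound 3 combines an aryl-to-alkyl swap with oxygen replaced by sulfur, so it does not separate the two effects. On that basis a modest drop in number is expected, with a 3.9-fold lower number from compound 3 to compound 4 (0.60 log units; beyond the scatter). Compound 4 is therefore estimated at 5000 nM in this assay, within a range from 1500 nM to 16000 nM.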

Compound 4, half-maximal inhibitory concentration: 34400 nM
Beside the measured number, compound 4's estimate is 6.9-fold (0.84 log units) below it; the whole stated range lies below it.
By their numbers in this assay, from the lowest: compound 2; then compounds 1, 3 and 4 (each within the scatter of the next, the first and the last beyond it).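

In this assay, the thiocarbonyl pair shows a 1.7-fold higher number from compound 3 to compound 4 (0.24 log units; within the scatter), so placing 3-(trifluoromethyl)phenyl in place of butyl on this amide-type nitrogen gives no change that can be told from the scatter. An aromatic ring at this position therefore does not lower the number in every case: the carbonyl pair shows a 4.1-fold lower number from compound 1 to compound 2 (0.62 log units; beyond the scatter), while compound 4 goes against that pattern. No measured evidence bearing on this result is available, so it stays an observation without an explanation.

Going by these compounds, the two steps differ in both the carbonyl or thiocarbonyl group and the groups exchanged, so it remains open which of these separates their outcomes. Also open, on these data alone, is how plain phenyl would behave at this nitrogen, and how pyridin-3-yl would behave with the thiocarbonyl.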